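Cyclohexyl to 3,5-dimethylphenyl on the shared core

The source may hold more compounds than are shown below. What is called first, only, known or untested is meant among the compounds shown, and "the series" means these compounds.

The study concerns inhibitors of 3-hydroxy-3-methylglutaryl-coenzyme A reductase built on one shared core. Compound 1 `CCc1nc(-c2ccccc2)cc(-c2ccc(F)cc2)c1/C=C/[C@@H]1C[C@@H](O)CC(=O)O1` gives 40 nM in an assay for inhibition of 3-hydroxy-3-methylglutaryl-coenzyme A reductase (Rattus norvegicus); on this read-out lower numbers stand for stronger inhibition and higher numbers for weaker inhibition. Within the data shown here, compound 2 `CC(C)c1nc(C2CCCCC2)cc(-c2ccc(F)cc2)c1/C=C/[C@@H]1C[C@@H](O)CC(=O)O1` gives 4 nM in this assay and stands lowest of the two numbers; its nearest neighbour, compound 1, is well outside the scatter, and the two compounds differ in more than one place, so no single step between them is drawn.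

Compound 3 `Cc1cc(C)cc(-c2cc(-c3ccc(F)cc3)c(/C=C/[C@@H]3C[C@@H](O)CC(=O)O3)c(C(C)C)n2)c1` has not yet been measured. It differs from compound 2 by 3,5-dimethylphenyl in place of cyclohexyl on an aromatic carbon. Compound 1, which carries an aromatic ring at that position, gives 40 nM, so a move from compound 2 toward a weaker number is expected, though only a modest one; the step of a 2.5-fold higher number from compound 2 to compound 3 (0.40 log units; beyond the scatter) is the estimate here. Compound 3 is thus expected to give 10 nM in this assay, within a range of 3 nM to 40 nM.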

Compound 3, half-maximal inhibitory concentration: 8 nM
The estimate for compound 3 lay 1.3-fold (0.10 log units) above the measured number; low and high end bracket the measured number.
By their numbers in this assay, from the lowest: compounds 2 and 3 (each within the scatter of the next); then compound 1.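

The step of a 2.0-fold higher number from compound 2 to compound 3 (0.30 log units; within the scatter) in this assay shows that, on this aromatic carbon next to the ring nitrogen, 3,5-dimethylphenyl and cyclohexyl cannot be told apart, although one ring is aromatic and the other is not. Compound 1 and compound 2 differ in more than one place and could not isolate this position, whereas this pair changes it alone, and an aromatic ring here need not carry a penalty beyond the scatter. Nothing shown explains why these two groups read alike.

Going by these compounds, it remains open how an open chain such as n-butyl, or a ring amine such as piperidine, would read at this position. Also open is how the ethyl group of compound 1, at 40 nM, would compare with isopropyl on an otherwise identical molecule, as no such pair is shown.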